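Replacing trifluoromethyl with phenoxy on the side ring

This account rests on a few compounds, and the source may have more. Where it says the series, first, only, none or still open, it means among the compounds named here.

Compound 1 `O=C(O)/C=C/c1ccc2noc(-c3ccc(OC(F)(F)F)cc3)c2c1`: 8370 nM
Compound 2 `O=C(O)/C=C/c1ccc2noc(-c3ccc(-c4ccccc4)cc3)c2c1`: 200 nM
Compound 3 `O=C(O)c1ccc2noc(-c3cccc(C(F)(F)F)c3)c2c1`: 4620 nM

Of the compounds shown here, three have been tested in an assay for inhibition of inositol hexakisphosphate kinase 3 (Homo sapiens), read by colorimetric assay, coupled enzyme assay and malachite green, with a stated time of 120 min, in the presence of a further agent that is not named here; a higher number here means a weaker inhibitor, a lower number a stronger inhibitor. Compound 3 stands second highest of the three numbers. Its nearest neighbour is compound 1, and the two values lie within the scatter of each other; compound 2 is far lower and well beyond the scatter.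

Compound 4 `O=C(O)c1ccc2noc(-c3cccc(Oc4ccccc4)c3)c2c1` is not yet measured. It differs from compound 3 in one place: phenoxy in place of trifluoromethyl on an aromatic carbon.

For the measured compounds named here, only one measured step speaks to this kind of change. From compound 1 to compound 2 a small fluorinated group on the side ring gave way to a whole phenyl ring, and the number fell sharply, a 42-fold lower number from compound 1 to compound 2 (1.62 log units; beyond the scatter). The step from compound 3 to compound 4 likewise swaps a small fluorinated group for a group carrying a phenyl ring, though here joined through an oxygen and set on a different side of the ring, and on a core with a different acid. The same direction is therefore expected, but with less confidence in its size.

Compound 4 is expected to reach roughly 500 nM, likely between 150 nM and 1800 nM, a step of a 9.2-fold lower number from compound 3 to compound 4 (0.97 log units; beyond the scatter).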

Compound 4, half-maximal inhibitory concentration: 850 nM
Beside the measured number, compound 4's estimate is 1.7-fold (0.23 log units) below it; the measured number falls inside the stated range.
By their numbers in this assay, from the lowest: compound 2; then compound 4; then compounds 3 and 1 (each within the scatter of the next).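

In this assay, phenoxy in place of trifluoromethyl on the side ring gives a 5.4-fold lower number from compound 3 to compound 4 (0.74 log units; beyond the scatter), so at this place, meta to a large group, a substituent with an added aromatic ring is tolerated and goes with stronger inhibition. For the compounds shown here, the only earlier step of this kind involved a different group, a different place on the side ring and a different acid, so this result is the first direct reading of such a change on the core of compound 3. Nothing measured here shows what lies behind the lower number.

The compounds shown leave open whether the gain depends on the oxygen that links the new ring, a question that a directly attached phenyl or an amine nitrogen in place of that oxygen could address at this same place. They also leave open whether phenoxy at this place would give a step of similar size on the core with the longer unsaturated acid chain carried by compound 1 and compound 2.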